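Flipping one ring stereocentre in a biphenyl-ether sugar series

A few compounds are considered here, and "the series" means these few. Any claim that something is new, unique, unknown or untested is made for them only; others in the source may bear on it.

Three compounds share one core. Compound 1 `CO[C@H]1O[C@H](COc2ccc(-c3ccccc3)cc2)[C@@H](O)[C@H](O)[C@H]1Oc1ccccc1` gives 36000 nM in a functional assay on A549 cells (Homo sapiens) for cytotoxicity, read by MTT assay, with a stated time of 48 h; on this read-out lower numbers stand for an effect already at smaller amounts and higher numbers for an effect only at larger amounts of compound. Compound 2 `CO[C@H]1O[C@H](COc2ccc(-c3ccccc3)cc2)[C@@H](O)[C@H](O)[C@H]1Oc1ccccc1C(C)C` gives 33000 nM in this assay. Compound 3 `CO[C@@H]1O[C@H](COc2ccc(-c3ccccc3)cc2)[C@@H](O)[C@H](O)[C@H]1Oc1cccc(C(C)C)c1` gives 35000 nM in this assay. Among the measured compounds shown here, the only step measured between two compounds that differ in one place, the exchange a 1.1-fold lower number from compound 1 to compound 2 (0.04 log units; within the scatter), lies within the scatter. Compound 3 sits among compounds 1 and 2: its gap to compound 1 and its gap to compound 2 are both within the scatter, so no ordering among the three can be read from these numbers.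

Compound 4 `CO[C@H]1O[C@H](COc2ccc(-c3ccccc3)cc2)[C@@H](O)[C@H](O)[C@H]1Oc1cccc(C(C)C)c1` is the next compound. How compound 4 differs from compound 3: the two compounds have the same atoms and bonds and differ only in configuration as drawn: 1 of 5 stereo elements differ; a stereocentre at a saturated ring carbon is drawn R in compound 3 and S in compound 4. For the measured compounds named here, no measured step touches a change of configuration, so nothing measured bears directly on this move. Because compound 1 gives 36000 nM and compound 2 gives 33000 nM in this assay, both drawn with the same configuration at that carbon as compound 4 and both within the scatter of compound 3, no shift beyond the scatter is expected. For compound 4 the estimated step is no change at the digits printed from compound 3 to compound 4 (within the scatter). Compound 4 is therefore expected to give about 35000 nM in this assay, within a range from 17000 nM to 70000 nM.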

Compound 4, half-maximal effective concentration: 32000 nM
Compound 4: the middle estimate sits 1.1-fold (0.04 log units) above what was measured; low and high end bracket the measured number.
By their numbers in this assay, from the lowest: compounds 4, 2, 3 and 1 (each within the scatter of the next).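

Among the compounds shown here, compounds 3 and 4 give the first measured step for a change of configuration, and in this assay it reads a 1.1-fold lower number from compound 3 to compound 4 (0.04 log units; within the scatter) and so shows no readable effect of drawing this saturated ring carbon R or S, in a comparison that isolates that one carbon: the fact that compounds 3 and 4 differ only in the configuration as drawn. With this configuration in place, a 1.0-fold lower number from compound 2 to compound 4 (0.01 log units; within the scatter) accompanies the exchange of 2-isopropylphenyl for 3-isopropylphenyl, and a 1.1-fold lower number from compound 1 to compound 4 (0.05 log units; within the scatter) accompanies the addition of isopropyl to the phenyl ring. Neither where the isopropyl sits nor whether it is present moves the number beyond the scatter in these compounds.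

The compounds shown leave open whether this carbon would matter if an amine or a carboxylic acid stood in place of the isopropyl. They also leave open whether any change to the shared core would move the number beyond the scatter.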